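This account rests on a few compounds, and the source may have more. Where it says the series, first, only, none or still open, it means among the compounds named here.

Measured in a functional assay on HL-60 cells (Homo sapiens) for inhibition, read by resazurin assay, with a stated time of 72 h; a lower number here means a stronger inhibitor, a higher number a weaker inhibitor:
- compound 1 `CCOc1ccc(C2C(C3CC3)C(=O)N2c2cc(OC)c(OC)c(OC)c2)cc1`: 201 nM
- compound 2 `COc1ccc(C2C(C3CC3)C(=O)N2c2cc(OC)c(OC)c(OC)c2)cc1`: 156 nM
- compound 3 `COc1cc(N2C(=O)C(C3CC3)C2c2ccc(SC)cc2)cc(OC)c1OC`: 279 nM

Compound 1 does not stand apart from the other two: the number moves a 1.3-fold lower number from compound 1 to compound 2 (0.11 log units; within the scatter), and a 1.4-fold higher number from compound 1 to compound 3 (0.14 log units; within the scatter). Compound 4 `CCOc1ccc(C2CC(=O)N2c2cc(OC)c(OC)c(OC)c2)cc1` keeps the core of compound 1 but has hydrogen in place of cyclopropyl on a saturated ring carbon.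

The measured steps, including a 1.8-fold higher number from compound 2 to compound 3 (0.25 log units; within the scatter), all swap a group on the aromatic ring. None removes cyclopropyl, so they offer no direct guide. Removing a whole group is a larger structural change than those swaps, so a shift towards a higher number, meaning a weaker inhibitor, is expected in this assay, though its size is uncertain. The expected step is a 4.5-fold higher number from compound 1 to compound 4 (0.65 log units; beyond the scatter). For compound 4 the estimate is 900 nM, within an expected range from 250 nM to 4000 nM.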

Compound 4, half-maximal inhibitory concentration: 88 nM
Estimate against measurement, compound 4: 10-fold (1.01 log units) above; measured number below the stated range.
By their numbers in this assay, from the lowest: compounds 4, 2, 1 and 3 (each within the scatter of the next, the first and the last beyond it).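

In this assay, cyclopropyl is not required on this saturated ring carbon: replacing it with hydrogen gives a 2.3-fold lower number from compound 1 to compound 4 (0.36 log units; beyond the scatter) and points towards a stronger inhibitor. This is the only step among the compounds shown that lies beyond the scatter, and the earlier steps swapped only a group on the aromatic ring. No available evidence explains the shift.

Going by these compounds, whether methyl, a longer chain or an amine on this carbon would match hydrogen remains open. Also open, on these data alone, is whether the same swap would shift the number for the methoxy or methylsulfanyl compounds.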